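Two dichlorophenyl ureas: one measured, one expected

A few compounds are considered here, and "the series" means these few. Any claim that something is new, unique, unknown or untested is made for them only; others in the source may bear on it.

Measured compounds:
- compound 1, `CN(C)CCCNc1nc(-c2ccc(NC(=O)Nc3ccc(Cl)cc3)cc2)nc2c(Cl)c(Cl)sc12`: 1160 nM
- compound 2, `CN(C)CCCNc1nc(-c2ccc(NC(=O)Nc3ccc(Cl)cc3Cl)cc2)nc2c(Cl)c(Cl)sc12`: 3490 nM
- compound 3, `CN(C)CCNc1nc(-c2ccc(NC(=O)Nc3ccccc3Cl)cc2)nc2ccsc12`: 550 nM

All three were tested in a functional assay on MDA-MB-231 cells (Homo sapiens) for cytotoxicity, read by MTT assay, with a stated time of 72 h; on this read-out lower numbers stand for stronger inhibition and higher numbers for weaker inhibition. In this assay compound 3 gives the lowest number of the three, with compound 1 the nearest and compound 2 the furthest away; both gaps are beyond the usual scatter.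

Compounds 1 and 2 share one core and differ in one place, (chloro in place of hydrogen on an aromatic carbon); this change brought a 3.0-fold higher number from compound 1 to compound 2 (0.48 log units; beyond the scatter). Compound 3 has a different core, and the difference between the two cores is not broken down here.

Compound 4, `CN(C)CCNc1nc(-c2ccc(NC(=O)Nc3ccc(Cl)cc3Cl)cc2)nc2ccsc12`, has not yet been measured. It differs from compound 3 by chloro in place of hydrogen on an aromatic carbon. Among the measured compounds shown here, this is the same kind of change as the one from compound 1 to compound 2, though the surroundings of the place are not identical: in compound 2 the entering chloro sits ortho to a large group and meta to a chloro group, while in compound 4 it sits meta to a chloro group and para to a large group.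

Because a 3.0-fold higher number from compound 1 to compound 2 (0.48 log units; beyond the scatter) was measured for the closest comparison available, a step of similar size and direction is expected from compound 3 to compound 4, namely a 2.5-fold higher number from compound 3 to compound 4 (0.41 log units; beyond the scatter). On that basis compound 4 is estimated at 1400 nM in this assay, likely between 600 nM and 3500 nM.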

Compound 4, half-maximal inhibitory concentration: 2450 nM
For compound 4 the middle estimate is 1.8-fold (0.24 log units) below the measured one; the measured number falls inside the stated range.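

In this assay, the second chloro, which turns 2-chlorophenyl into 2,4-dichlorophenyl, gave a 4.5-fold higher number from compound 3 to compound 4 (0.65 log units; beyond the scatter). Set beside the earlier step, this change raises the number on both cores, and the size of the rise carries over from one core to the other as closely as repeated measurements can show: the same change on two cores in this assay, a 3.0-fold higher number (0.48 log units; beyond the scatter) from compound 1 to compound 2 and a 4.5-fold higher number (0.65 log units; beyond the scatter) from compound 3 to compound 4, 1.5-fold (0.17 log units) apart, within the scatter of two such steps. Among the compounds shown here, this rests on only two pairs in a single cell assay, the surroundings of the place where the chloro enters are not identical in the two pairs, and nothing here shows why the number rises or whether it would also rise on a third core.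

The compounds shown leave open whether this rise belongs to chloro itself or would also appear with another group in the same place, such as fluoro, methyl or methoxy. They also leave open whether the step would keep its size if the side chain ended in a different amine, such as morpholine or piperidine, instead of the one carried by these four compounds.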